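Methoxy in Place of Methyl on the Outer Phenyl

A few compounds are considered here, and "the series" means these few. Any claim that something is new, unique, unknown or untested is made for them only; others in the source may bear on it.

Compound 2 `Cc1ccc(-n2cc(NC(=O)c3cccc(NS(=O)(=O)c4ccc(Cl)cc4)c3)cn2)cc1` gives 4570 nM in a functional assay on HeLa cells (Homo sapiens) for inhibition, read by MTT assay, with a stated time of 48 h; on this read-out lower numbers stand for stronger inhibition and higher numbers for weaker inhibition. Compound 1 `O=C(Nc1cnn(-c2ccccc2)c1)c1cccc(NS(=O)(=O)c2ccc(Cl)cc2)c1` gives 5410 nM in this assay, and the two numbers lie within the scatter of each other, as the step of a 1.2-fold lower number from compound 1 to compound 2 (0.07 log units; within the scatter) shows. Compound 3 `COc1ccc(-n2cc(NC(=O)c3cccc(NS(=O)(=O)c4ccc(Cl)cc4)c3)cn2)cc1` differs from compound 2 by methoxy in place of methyl on an aromatic carbon. Within the data shown here, the only measured step touching this position, from hydrogen to methyl, was small, so compound 3 is expected to show no step beyond the scatter, an expected step of a 1.1-fold lower number from compound 2 to compound 3 (0.04 log units; within the scatter). The estimate for compound 3 in this assay is 4200 nM, with a range from 1500 nM to 12000 nM.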

Compound 3, half-maximal inhibitory concentration: 19700 nM
Compound 3: middle estimate off by 4.7-fold (0.67 log units), on the low side; the whole stated range lies below it.
By their numbers in this assay, from the lowest: compounds 2 and 1 (each within the scatter of the next); then compound 3.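

In this assay this position proves sensitive to the group it carries: methoxy in place of methyl gives a 4.3-fold higher number from compound 2 to compound 3 (0.63 log units; beyond the scatter) and so moves the number beyond the scatter, which hydrogen to methyl did not do. Methoxy in place of hydrogen points the same way, with a 3.6-fold higher number from compound 1 to compound 3 (0.56 log units; beyond the scatter) on the same read-out. Nothing available here explains this result.

The compounds shown leave open how an amine or a hydroxyl at this position would read, and whether a longer ether chain would raise the number further.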